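Swapping the ring at the end of the chain

The source may report more compounds than this note shows. Statements on the series, on what has been measured and on what is new or still open speak of the compounds shown alone.

For the measured compounds named here, compound 1 `Cn1c(=O)c2[nH]c(-c3ccc(OCCC4CCNCC4)cc3)nc2n(C)c1=O` is the only member of this small set with a number attached: in an assay on CHO cells for binding affinity to adenosine receptor A2b (Homo sapiens), with a stated time of 20 min (a lower number here means a stronger inhibitor, a higher number a weaker inhibitor), compound 1 gives 2.9 nM. The other two values are limits of the assay rather than numbers. Compound 2 `Cn1c(=O)c2[nH]c(Cc3ccc(OCCCCl)cc3)nc2n(C)c1=O` is reported in this assay only as > 10 nM, a limit. Compound 3 `Cn1c(=O)c2[nH]c(Cc3ccc(OCCCN4CCC5(CC4)OCCO5)cc3)nc2n(C)c1=O` is likewise reported in this assay only as > 10 nM, again a limit. Going by the values given here, the one change between measured compounds, a step that the two limits leave unreadable from compound 2 to compound 3, therefore cannot be sized, because both ends sit at the limit of > 10 nM in this assay, at which 2 of the 3 values shown sit.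

Compound 4 `Cn1c(=O)c2[nH]c(-c3ccc(OCCCn4ccnc4)cc3)nc2n(C)c1=O` differs from compound 1 by (1H-imidazol-1-yl)methyl in place of piperidin-4-yl on a saturated chain carbon, two bonds along the chain from an oxygen on an aromatic ring. Among the compounds with values here, no measured step speaks directly to this exchange: the step from compound 2 to compound 3 also alters the end of the chain, but it is unreadable, and those two compounds carry a different link between the shared core and the aromatic ring. The expectation must therefore rest on compound 1 alone, with an expected step of a 5.2-fold higher number from compound 1 to compound 4 (0.71 log units; beyond the scatter) in this assay. Compound 4 is estimated to give about 15 nM, with a likely range from 3 nM to 60 nM.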

Compound 4, inhibition constant: 1.05 nM
Compound 4: the middle estimate sits 14-fold (1.15 log units) above what was measured; the whole stated range lies above it.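

In this assay, exchanging piperidin-4-yl for (1H-imidazol-1-yl)methyl on a saturated chain carbon, two bonds along the chain from an oxygen on an aromatic ring, gives a 2.8-fold lower number from compound 1 to compound 4 (0.44 log units; beyond the scatter). For the compounds shown here, this is the first change at the end of the chain whose size can be read, and it shows that the non-aromatic ring of compound 1 can give way to a five-membered aromatic ring without the number rising. The group that enters counts no hydrogen-bond donor where the group that leaves counts one, so that donor is not required for a low number in this pair, although nothing measured here says which difference between the two groups produces the step.

As far as these compounds go, the step from compound 2 to compound 3 still cannot be read, so it remains open whether the end of the chain matters in the same way in compounds with the other link from the shared core to the aromatic ring. Also open, from the compounds shown here alone, is how a dimethylamino group, a pyridine ring or a longer chain would compare at the same place.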